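The source may report more compounds than this note shows. Statements on the series, on what has been measured and on what is new or still open speak of the compounds shown alone.

Working notes on the series, read in an ADME assay on HUVEC cells (Homo sapiens) for cytotoxicity, read by MTT assay, with a stated time of 16 h; a lower number here means a stronger inhibitor, a higher number a weaker inhibitor. Compound 1 `COc1cc(C2Oc3cc([C@H]4Oc5cc(OC(=O)c6cc(O)c(O)c(O)c6)cc(O)c5C(=O)[C@@H]4O)ccc3OC2CO)ccc1O` gives 9210 nM, and compound 2 `COc1cc([C@@H]2Oc3cc([C@H]4Oc5cc(OC(=O)c6cc(O)c(O)c(O)c6)cc(O)c5C(=O)[C@@H]4O)ccc3O[C@H]2CO)ccc1O` gives 7850 nM, so compound 2 stands level with compound 1 within the scatter. Compound 3 `COc1cc([C@H]2Oc3cc([C@H]4Oc5cc(OC(=O)c6cc(O)c(O)c(O)c6)cc(O)c5C(=O)[C@@H]4O)ccc3O[C@@H]2CO)ccc1O` has not yet been measured. Its relation to compound 2 is purely one of configuration as drawn: the two compounds have the same atoms and bonds and differ only in configuration as drawn: 2 of 4 stereo elements differ; a stereocentre at a saturated ring carbon is drawn S in compound 2 and R in compound 3; a stereocentre at a saturated ring carbon is drawn S in compound 2 and R in compound 3. Within the data shown here, one measured step bears on this change, a 1.2-fold lower number from compound 1 to compound 2 (0.07 log units; within the scatter), and it rests on (the fact that one of compounds 1 and 2 is drawn with a defined configuration and the other without, at the place where they differ). That step also involves only configuration at saturated ring carbons, and it stays within the scatter. On that single step, no change beyond the scatter is expected in this assay, and no direction is favoured with any confidence. The expected step is a 1.1-fold higher number from compound 2 to compound 3 (0.06 log units; within the scatter). For compound 3 the estimated value is 9000 nM, with an expected range of 5000 nM to 16000 nM.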

Compound 3, half-maximal inhibitory concentration: 17100 nM
Estimate against measurement, compound 3: 1.9-fold (0.28 log units) below; the whole stated range lies below it.
By their numbers in this assay, from the lowest: compounds 2, 1 and 3 (each within the scatter of the next, the first and the last beyond it).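

Configuration at the two saturated ring carbons registers in this assay: inverting both gives a 2.2-fold higher number from compound 2 to compound 3 (0.34 log units; beyond the scatter), the first step in the series beyond the scatter, and it rests on stereochemistry alone: the fact that compounds 2 and 3 differ only in the configuration as drawn Compound 1, drawn without a configuration at these two carbons, is not separated from compound 3, with a 1.9-fold higher number from compound 1 to compound 3 (0.27 log units; within the scatter), and this comparison sets an undefined drawing against a defined one: the fact that one of compounds 1 and 3 is drawn with a defined configuration and the other without, at the place where they differ Only the two fully defined drawings are therefore separated beyond the scatter, and only modestly.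

From the compounds shown here alone, both carbons change together in this pair, so it stays open whether one of them alone carries the step or both are needed. Also open, going by these compounds, is whether the same gap between the two configurations persists with an amide in place of the ester.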